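Shortening the amide linker on two different cores

This account rests on a few compounds, and the source may have more. Where it says the series, first, only, none or still open, it means among the compounds named here.

Compound 1 `Nc1ccccc1NC(=O)/C=C/c1ccc(Cn2cnc3c(Nc4cccc(OC(F)(F)F)c4)nc(Cl)nc32)cc1` and compound 3 `Nc1ccccc1NC(=O)c1ccc(Cn2cnc3c(Nc4cccc(OC(F)(F)F)c4)nc(Cl)nc32)cc1` share one core and differ in a single place: (2-aminophenyl)carbamoyl in place of 2-((2-aminophenyl)carbamoyl)ethenyl on an aromatic carbon. In a functional assay on NCI-H460 cells (Homo sapiens) for antiproliferative activity, read by CCK-8 assay, with a stated time of 72 h, tested at 2 uM (on this read-out lower numbers stand for a weaker effect and higher numbers for a stronger effect at the one concentration tested), compound 1 gives 2.1%, whereas compound 3 gives 47.7%, a step of a number 45.6 percentage points higher from compound 1 to compound 3 (beyond the scatter). Compound 2 `CCCCn1cnc2c(Nc3ccccc3)nc(NCOCc3ccc(/C=C/C(=O)Nc4ccccc4N)cc3)nc21` is built on another core; the difference between the two cores is not broken down here. In this assay compound 2 gives 23.1%. Compound 4 `CCCCn1cnc2c(Nc3ccccc3)nc(NCOCc3ccc(C(=O)Nc4ccccc4N)cc3)nc21` has not yet been measured and differs from compound 2 by the same change, ((2-aminophenyl)carbamoyl in place of 2-((2-aminophenyl)carbamoyl)ethenyl on an aromatic carbon), in the same place. Within the data shown here, compound 4 is expected to move by a number 34.9 percentage points higher from compound 2 to compound 4 (beyond the scatter), resting on the single measured step of a number 45.6 percentage points higher from compound 1 to compound 3 (beyond the scatter), with room kept because that step a number 45.6 percentage points higher from compound 1 to compound 3 (beyond the scatter) was seen on one core only. In this assay compound 4 is estimated at 58%, between 33% and 80%.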

Compound 4, a percentage reported as inhibition, at one concentration (the size of the read-out at that concentration, not a potency): 27.7%
Beside the measured number, compound 4's estimate is 30.3 percentage points above it, outside the stated range (below it).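

In this assay, the change that shortens the linker gives a number 4.6 percentage points higher from compound 2 to compound 4 (within the scatter). Among these compounds, its size therefore does not carry over from one core to the other, and the large rise seen on the core of compound 1 cannot be assumed for this series as a whole: the same change on two cores in this assay, a number 45.6 percentage points higher (beyond the scatter) from compound 1 to compound 3 and a number 4.6 percentage points higher (within the scatter) from compound 2 to compound 4, 41 percentage points apart, beyond the scatter of two such steps With only one pair on each core, this does not show which difference between the cores sets the size of the step, nor how the change would behave on any third core.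

The compounds shown leave open what a saturated chain in place of the ethenyl link would do on either core. They also leave open whether a hydroxamic acid in place of the 2-aminophenyl amide would respond to the core in the same way.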